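Replacing the tert-butylamino Group with a Piperidine Ring

A few compounds are considered here, and "the series" means these few. Any claim that something is new, unique, unknown or untested is made for them only; others in the source may bear on it.

Measured so far:
Compound 1, `O=C(CNc1ccc(F)cc1)Nc1nc2ccc(Cl)cc2s1`, gives 100 mg/kg.
Compound 2, `CC(C)(C)NCC(=O)Nc1nc2ccc(Cl)cc2s1`, gives 100 mg/kg.
Compound 3, `COc1ccc(/C=N/NC(=S)Nc2nc3ccc(Cl)cc3s2)cc1`, gives 300 mg/kg.

All three compounds share one core and differ only in the group attached to it. In a functional assay on the whole organism with Mus musculus as the target, in the maximal electroshock model, with a stated time of 4 h (on this read-out lower numbers stand for an effect already at smaller amounts and higher numbers for an effect only at larger amounts of compound), compound 2 stands level with compound 1 at the digits shown, and together these two give the lowest numbers of the three; compound 3 sits at a higher number, beyond the scatter.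

Compound 4, `O=C(CN1CCCCC1)Nc1nc2ccc(Cl)cc2s1`, has not yet been measured. It arises from compound 2 by the change (piperidin-1-yl in place of (tert-butyl)amino on a saturated chain carbon bound to a carbonyl carbon). For the measured compounds named here, no measured pair repeats this exact change. The closest guide is the step of no change at the digits printed from compound 1 to compound 2 (within the scatter), where one group on the amine nitrogen gave way to a quite different one without any shift in the result. That suggests the amine end of this chain tolerates variation, though one step cannot prove a pattern, and compound 3 shows that larger changes elsewhere do move the number.

On that basis compound 4 is expected to land near compound 2, with an estimated step of no change at the digits printed from compound 2 to compound 4 (within the scatter). The estimate for compound 4 is 100 mg/kg, with a range from 50 mg/kg to 300 mg/kg.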

Compound 4, minimum effective dose in the Mus musculus assay: 100 mg/kg
Beside the measured number, compound 4's estimate shows no gap at the digits printed, and the stated range covers the measured number.
By their numbers in the Mus musculus assay, from the lowest: compounds 1, 2 and 4 (each within the scatter of the next); then compound 3.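

In the Mus musculus assay, piperidin-1-yl in place of (tert-butyl)amino on a saturated chain carbon bound to a carbonyl carbon gives no change at the digits printed from compound 2 to compound 4 (within the scatter) and so adds a second change at this place that leaves the number where it was. This change differs in kind from the earlier step: the amine nitrogen now sits in a six-membered non-aromatic ring, and the hydrogen-bond donor count goes from 1 to 0, so the read-out holds without the hydrogen on that nitrogen. In a physicochemical assay for lipophilicity, in phosphate buffer, measured as octanol-water partition (on this read-out lower numbers stand for lower lipophilicity and higher numbers for higher lipophilicity), compound 2 gives 3.02 and compound 4 gives 3.16, a step of a number 0.14 log units higher from compound 2 to compound 4 (within the scatter) that shows the swap also leaves this second read-out level. Nothing available explains why the whole-animal number stays put.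

All the groups shown at this place share one number, so it remains open whether any group here can lower it. A morpholine ring, a smaller pyrrolidine ring, a dimethylamino group or a longer chain between the carbonyl and the amine could each test how far this tolerance extends.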